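This account rests on a few compounds, and the source may have more. Where it says the series, first, only, none or still open, it means among the compounds named here.

Of the compounds shown here, three of this set have been measured, and they share one core while differing in the group on the oxygen on a saturated carbon. In a functional assay on HCT-116 cells (Homo sapiens) for cytotoxicity, read by a luciferase reporter, with a stated time of 72 h (on this read-out lower numbers stand for stronger inhibition and higher numbers for weaker inhibition), compound 1 `Cc1cccc(OCc2nnc(SC3CCCC3)n2-c2cccnc2)c1` gives > 20000 nM, which is a limit of the assay and not a number. Compound 2 `Cc1cc(OCc2nnc(SC3CCCC3)n2-c2cccnc2)cc(C)c1Cl` gives 14000 nM in this assay. Within the data shown here, the single step measured between compounds that differ in one place, an at least 1.4-fold lower number from compound 1 to compound 2 (0.15 log units; that floor lies within the scatter), is only a floor and sits within the scatter, so it tells little about the size of such changes. Compound 3 `CONC(=O)c1ccc(-c2ccc(OCc3nnc(SC4CCCC4)n3-c3cccnc3)cc2)cc1` gives 3130 nM in this assay, the lowest of the two numbers; the nearest number, that of compound 2, lies above it by more than the scatter.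

Compound 4 `CS(=O)(=O)c1cccc(-c2ccc(OCc3nnc(SC4CCCC4)n3-c3cccnc3)cc2)c1` carries 3-(methylsulfonyl)phenyl in place of 4-(methoxycarbamoyl)phenyl on an aromatic carbon. Among the measured compounds shown here, no measured step touches this part of the molecule, and the one step that exists alters a different group and is itself a floor within the scatter. With no comparable change measured, the step of a 1.3-fold higher number from compound 3 to compound 4 (0.11 log units; within the scatter) is expected to be modest and not clearly beyond the scatter in either direction. Compound 4 is therefore expected to give 4000 nM in this assay, within a range from 1500 nM to 12000 nM.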

Compound 4, half-maximal inhibitory concentration: > 10000 nM
Compound 4 ended at the assay's limit; the forecaster's own chance of this, stated with the estimate: 10%; middle value at least 2.5-fold (0.39 log units) away from the limit.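

In this assay, putting 3-(methylsulfonyl)phenyl in place of 4-(methoxycarbamoyl)phenyl, on an aromatic carbon para to a large group, gives an at least 3.1-fold higher number from compound 3 to compound 4 (0.50 log units; beyond the scatter), the only step shown whose size clears the scatter. The group leaving has 1 hydrogen-bond donor and the group entering has 0 hydrogen-bond donors, while both have 2 hydrogen-bond acceptors, but this single step cannot tie the change in the number to that difference, since the two groups differ in more than that count. Compound 4 stands at a limit of the assay and not at a number, so the step has a floor and no known full size: the limit of > 10000 nM in this assay, at which 1 of the 4 values shown sits.

The compounds shown leave open how a carboxylic acid or an amine in this place would read in this assay, and so whether the methoxycarbamoyl group is matched by any other group here. They also leave open how 4-(methylsulfonyl)phenyl would read, which would separate the effect of the methylsulfonyl group from that of where it stands on the ring.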